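Amide-side swap on a dichlorinated aryl core

A few compounds are considered here, and "the series" means these few. Any claim that something is new, unique, unknown or untested is made for them only; others in the source may bear on it.

Compound 1 `O=C(Nc1ccc(Cl)c(-c2nnc3c(Cl)cccn23)c1)c1ccccn1` gives 92000 nM in a functional assay on MDA-MB-231 cells (Homo sapiens) for antiproliferative activity, read by MTT assay, with stated times of 72 h and 4 h; on this read-out higher numbers stand for weaker inhibition and lower numbers for stronger inhibition. Compound 2 `O=C(Nc1ccc(Cl)c(-c2nnc3c(Cl)cccn23)c1)c1cccc(Cl)c1` gives 66100 nM in this assay. Compound 3 `CS(=O)(=O)c1ccc(C(=O)Nc2ccc(Cl)c(-c3nnc4c(Cl)cccn34)c2)c(Cl)c1` gives 37200 nM in this assay.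

Compound 2 holds the second highest of the three numbers. Its nearest neighbour is compound 1, with a 1.4-fold lower number from compound 1 to compound 2 (0.14 log units; within the scatter); compound 3 stands furthest, and its value lies within the scatter of the value of compound 2 as well.

Compound 4 `O=C(Nc1ccc(Cl)c(-c2nnc3c(Cl)cccn23)c1)c1c(F)cccc1Cl` differs from compound 2 by 2-chloro-6-fluorophenyl in place of 3-chlorophenyl on a carbonyl carbon. For the measured compounds named here, only one measured step touches the same carbonyl carbon, a 1.4-fold lower number from compound 1 to compound 2 (0.14 log units; within the scatter), and it stayed within the scatter. On that basis compound 4 is expected to show no step beyond the scatter in this assay, giving a 1.1-fold lower number from compound 2 to compound 4 (0.04 log units; within the scatter). Compound 4 is therefore estimated at 60000 nM, between 25000 nM and 140000 nM.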

Compound 4, half-maximal inhibitory concentration: > 100000 nM
Compound 4 ended at the assay's limit (the forecaster's own chance of this, stated with the estimate: 10%); middle value at least 1.6-fold (0.22 log units) from the limit.
By their numbers in this assay, from the lowest: compounds 3, 2 and 1 (each within the scatter of the next, the first and the last beyond it). At a limit, above all of these: compound 4.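

In this assay compound 4 gives > 100000 nM, which is a limit and not a number. Against the two earlier groups on this carbonyl carbon, the change reads as an at least 1.5-fold higher number from compound 2 to compound 4 (0.17 log units; that floor lies within the scatter) and as an at least 1.0-fold higher number from compound 1 to compound 4 (0.03 log units; that floor lies within the scatter). Both are only floors, so 2-chloro-6-fluorophenyl is the one group shown here with no measured number, and a real loss can be neither claimed nor excluded.

It stays open whether an amine or a carboxylic acid on this carbonyl carbon would give a number beyond the scatter of those shown.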